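This account rests on a few compounds, and the source may have more. Where it says the series, first, only, none or still open, it means among the compounds named here.

Working notes on the series. Compound 1 `N/C(=N\NC(=S)N1CCCCCC1)c1ccccn1` and compound 2 `Cc1ccnc(/C(N)=N/NC(=S)N2CCCCCC2)c1` share one core and differ only by a methyl on the aromatic ring. In a functional assay on A-375 cells (Homo sapiens) for cytotoxicity, read by MTT assay, with a stated time of 72 h (on this read-out higher numbers stand for weaker inhibition and lower numbers for stronger inhibition), compound 1 gives 740 nM; in this assay compound 2 gives 800 nM. Compound 1 carries the lower of the two numbers, but the pair sits within the scatter, as the step shows: a 1.1-fold higher number from compound 1 to compound 2 (0.03 log units; within the scatter).

Compound 3 `Cc1cccc(/C(N)=N/NC(=S)N2CCCCCC2)n1` has not yet been measured. It differs from compound 1 by methyl in place of hydrogen on an aromatic carbon. For the measured compounds named here, the only measured step that bears on this kind of change is a methyl added to the same ring, namely a 1.1-fold higher number from compound 1 to compound 2 (0.03 log units; within the scatter), which stayed within the scatter. On that basis no step beyond the scatter is expected from compound 1 to compound 3 in this assay. The expected step is a 1.0-fold higher number from compound 1 to compound 3 (0.01 log units; within the scatter). The estimate for compound 3 in this assay is 750 nM, with an expected range from 350 nM to 1600 nM. With a single supporting step the range is kept wide.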

Compound 3, half-maximal inhibitory concentration: 1800 nM
Estimate against measurement, compound 3: 2.4-fold (0.38 log units) below; the measured number lies above the stated range.
By their numbers in this assay, from the lowest: compounds 1 and 2 (each within the scatter of the next); then compound 3.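

In this assay, methyl in place of hydrogen on an aromatic carbon next to the ring nitrogen and meta to a large group gives a 2.4-fold higher number from compound 1 to compound 3 (0.39 log units; beyond the scatter), a modest move towards weaker inhibition. The earlier methyl step, a 1.1-fold higher number from compound 1 to compound 2 (0.03 log units; within the scatter), stayed within the scatter, so the same exchange of hydrogen for methyl on this ring does not have one outcome across the two steps shown, and the place of the methyl in compound 3 is the only one here with a step beyond the scatter. Nothing available explains why the two ring places differ.

From the compounds shown here alone, it remains open whether this loss belongs to methyl alone or to any group placed next to the ring nitrogen, a question that an ethyl, a methoxy or an amine at that carbon would bear on. Going by these compounds, with a single methyl step at this place and one cell assay, it also remains open whether the same step would appear on a different core or in other cells.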